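Swapping the Aryl Group of Compound 3 for Furan-2-yl

This account rests on a few compounds, and the source may have more. Where it says the series, first, only, none or still open, it means among the compounds named here.

Of the compounds shown here, three built on a shared core have been measured in a functional assay on U-251 cells (Homo sapiens) for inhibition, read by sulforhodamine B assay, with a stated time of 48 h (on this read-out lower numbers stand for stronger inhibition of growth and higher numbers for weaker inhibition of growth), so far. Compound 1 `COc1ccc(/C=N/NC(=S)NC(C)(C)[C@H]2CC=C(C)CC2)cc1` gives 71900 nM in this assay. For compound 2 `CC1=CC[C@H](C(C)(C)NC(=S)N/N=C/c2ccc(O)cc2)CC1` this assay reports only a limit of > 100000 nM rather than a number. Compound 3 `CC1=CC[C@H](C(C)(C)NC(=S)N/N=C/c2cccc(Cl)c2)CC1` gives 35800 nM in this assay and stands lowest of the two numbers available; its nearest neighbour is compound 1, the gap being a 2.0-fold lower number from compound 1 to compound 3 (0.30 log units; within the scatter) while the step of an at least 2.7-fold lower number from compound 2 to compound 3 (0.44 log units; beyond the scatter) is the only one beyond the scatter. Compound 4 `CC1=CC[C@H](C(C)(C)NC(=S)N/N=C/c2ccco2)CC1` is not yet measured and differs from compound 3 in one place: furan-2-yl in place of 3-chlorophenyl on a carbon with a double bond to nitrogen in the words of the comparison. The measured steps that alter the group on that same carbon, namely a 2.0-fold lower number from compound 1 to compound 3 (0.30 log units; within the scatter) and an at least 2.7-fold lower number from compound 2 to compound 3 (0.44 log units; beyond the scatter) together with an at least 1.3-fold higher number from compound 1 to compound 2 (0.14 log units; that floor lies within the scatter) elsewhere, all stay small to modest, so no large move is expected. The step of a 1.7-fold higher number from compound 3 to compound 4 (0.22 log units; within the scatter) is therefore expected to be small and slightly upward. Compound 4 is estimated at 60000 nM in this assay, with a range from 20000 nM to 180000 nM in this assay.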

Compound 4, concentration for total growth inhibition: 81500 nM
The estimate for compound 4 lay 1.4-fold (0.13 log units) below the measured number; the measured number falls inside the stated range.
By their numbers in this assay, from the lowest: compounds 3, 1 and 4 (each within the scatter of the next, the first and the last beyond it). At a limit, above all of these: compound 2.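

In this assay the position on the carbon with a double bond to nitrogen now responds to a change of ring type: a 2.3-fold higher number from compound 3 to compound 4 (0.36 log units; beyond the scatter) and so furan-2-yl cannot stand in for 3-chlorophenyl without a step beyond the scatter. Set against 4-methoxyphenyl, the same five-membered ring shows no readable difference, with a 1.1-fold higher number from compound 1 to compound 4 (0.05 log units; within the scatter) as the printed step. Set against 4-hydroxyphenyl, the step is only a floor, an at least 1.2-fold lower number from compound 2 to compound 4 (0.08 log units; that floor lies within the scatter) and compound 2 gives a limit and not a number: the limit of > 100000 nM in this assay, at which 1 of the 4 values shown sits.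

As far as these compounds go, whether 4-chlorophenyl or thiophen-2-yl would stay as low as compound 3 remains open. So does the effect of an amine or a carboxylic acid on the aromatic ring at this position.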